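The source may hold more compounds than are shown below. What is called first, only, known or untested is meant among the compounds shown, and "the series" means these compounds.

Working notes on the shared core of compound 3 `O=S(=O)(Nc1ccccn1)c1ccc(N/C(S)=N\c2ccnc3cc(C(F)(F)F)ccc23)cc1`, where the substituent on the sulfonamide nitrogen is varied. In a functional assay on AS49-RAW cells (Homo sapiens) for antiproliferative activity, read by sulforhodamine B assay, with a stated time of 48 h (a higher number here means a weaker inhibitor, a lower number a stronger inhibitor), compound 3 gives 33500 nM. Among the three numbers measured so far this is the second highest; compound 2 `Cc1noc(NS(=O)(=O)c2ccc(N/C(S)=N\c3ccnc4cc(C(F)(F)F)ccc34)cc2)c1C` gives 34000 nM in this assay, and compound 1 `N=C(N)NS(=O)(=O)c1ccc(N/C(S)=N\c2ccnc3cc(C(F)(F)F)ccc23)cc1` gives 23900 nM in this assay. All three values sit within the scatter of one another, so no ordering can be read from them.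

The next compound, compound 4 `COc1cc(NS(=O)(=O)c2ccc(N/C(S)=N\c3ccnc4cc(C(F)(F)F)ccc34)cc2)nc(OC)n1`, differs from compound 3 in one place: 2,6-dimethoxypyrimidin-4-yl in place of pyridin-2-yl on a sulfonamide nitrogen. Each earlier exchange at this same nitrogen was small: a 1.4-fold higher number from compound 1 to compound 3 (0.15 log units; within the scatter), a 1.0-fold lower number from compound 2 to compound 3 (0.01 log units; within the scatter), and a 1.4-fold higher number from compound 1 to compound 2 (0.15 log units; within the scatter). Neither a ring with one hetero atom nor a ring with two hetero atoms moved the number beyond the scatter relative to the non-ring group of compound 1, so there is no basis in these data for expecting the 2,6-dimethoxypyrimidin-4-yl group to do otherwise.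

For compound 4 the step is therefore expected to be a 1.1-fold lower number from compound 3 to compound 4 (0.03 log units; within the scatter), with no change beyond the scatter. Compound 4 is estimated at 31000 nM in this assay, with a range from 12000 nM to 80000 nM.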

Compound 4, half-maximal inhibitory concentration: 64500 nM
The estimate for compound 4 lay 2.1-fold (0.32 log units) below the measured number; measured number inside the range.
By their numbers in this assay, from the lowest: compounds 1, 3, 2 and 4 (each within the scatter of the next, the first and the last beyond it).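

In this assay, a 1.9-fold higher number from compound 3 to compound 4 (0.28 log units; within the scatter) and a 1.9-fold higher number from compound 2 to compound 4 (0.28 log units; within the scatter) both stay within the scatter, so at this sulfonamide nitrogen 2,6-dimethoxypyrimidin-4-yl cannot be told apart from pyridin-2-yl or from 3,4-dimethyl-1,2-oxazol-5-yl. Within the data shown here, what the earlier compounds did not show is a step at this nitrogen beyond the scatter: a 2.7-fold higher number from compound 1 to compound 4 (0.43 log units; beyond the scatter) is such a step, though a modest one, and it sets the 2,6-dimethoxypyrimidin-4-yl group against the non-ring group of compound 1. Nothing available here bears on why this one exchange reaches past the scatter when the exchanges to compound 2 and compound 3 do not.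

Going by these compounds, with compound 2 and compound 3 lying within the scatter of both compound 1 and compound 4, it stays open whether the ring itself, its two methoxy groups or the pyrimidine ring accounts for the step from compound 1. Also open, on these data alone, is how a 2-methoxypyridine, an unsubstituted pyrimidin-4-yl or a plain methyl on this nitrogen would read in this assay, and whether any group here can move the number well clear of the scatter.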